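A single numbered cytotoxicity value and two limits

The source may report more compounds than this note shows. Statements on the series, on what has been measured and on what is new or still open speak of the compounds shown alone.

Compound 3 `Cc1nc([N+](=O)[O-])cn1CC(O)CN1CCN(c2cccc(Cl)c2Cl)CC1` is the only one of the three measured compounds with a number in a toxicity assay on HeLa cells (Homo sapiens) for cytotoxicity, read by MTT assay, with a stated time of 24 h (on this read-out higher numbers stand for weaker inhibition and lower numbers for stronger inhibition), where compound 3 gives 3620000 nM. Compound 1 `COc1ccccc1N1CCN(C(=S)SCC(O)Cn2c([N+](=O)[O-])cnc2C)CC1` reaches only a limit of the assay, > 5000000 nM. Compound 2 `Cc1ncc([N+](=O)[O-])n1CC(O)CN1CCN(c2cccc(Cl)c2Cl)CC1` likewise reaches only a limit, > 5000000 nM. Within the data shown here, the one measured step, an at least 1.3-fold lower number from compound 2 to compound 3 (0.14 log units; that floor lies within the scatter), stays within the scatter. Two of the three values sit at the same limit (the limit of > 5000000 nM in this assay, at which 2 of the 3 values shown sit). Compound 4 `CCN1CCN(CC(O)Cn2cc([N+](=O)[O-])nc2C)CC1` differs from compound 3 in one place: ethyl in place of 2,3-dichlorophenyl on an amine nitrogen in a ring. No measured step touches this position, so the expectation rests only on the weak inhibition shown by all three compounds. For compound 4 the step of a 1.7-fold higher number from compound 3 to compound 4 (0.22 log units; within the scatter) is expected. The estimate for compound 4 is 6000000 nM, between 2000000 nM and 20000000 nM.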

Compound 4, half-maximal inhibitory concentration: > 5000000 nM
Compound 4: no number, only a limit; the forecaster's own chance of this, stated with the estimate: 70%; the middle value does not contradict the limit.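

Changing 2,3-dichlorophenyl to ethyl on an amine nitrogen in a ring gives an at least 1.3-fold higher number from compound 3 to compound 4 (0.14 log units; that floor lies within the scatter), the first step read at this position, and in this assay it shows no change beyond the scatter. Losing the aromatic ring here therefore brings no measurable gain in inhibition. The result for compound 4 is a limit and not a number, so the true size of the step remains unknown, and the set now rests even more on one limit: the limit of > 5000000 nM in this assay, at which 3 of the 4 values shown sit.

Going by these compounds, it remains open whether a carboxylic acid, a primary amine or a longer chain on this nitrogen would shift the number in this assay. On these data alone, it also remains open whether ethyl behaves the same way with 2-methyl-5-nitro-1H-imidazol-1-yl in place of the 2-methyl-4-nitro-1H-imidazol-1-yl group.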